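Two-ring acetal series: ester and aryl variation

The compounds below may be only part of what the source reports. "The series", "measured", "known", "first", "only" and "open" are said of these compounds alone.

Compound 2 `C=C(C)[C@H]1CC=C(C)[C@@]2(O)[C@@H]1[C@H](c1ccccn1)O[C@@H]2C(=O)OC` carries a pyridin-2-yl group and a methyl ester. In a functional assay on KB3 cells (Homo sapiens) for antiproliferative activity, read by MTT assay, with a stated time of 96 h (on this read-out lower numbers stand for stronger inhibition and higher numbers for weaker inhibition), compound 2 gives 100000 nM. Among the compounds with values here, the only other number, from compound 1 `C=C(C)[C@H]1CC=C(C)[C@@]2(O)[C@@H]1[C@H](c1ccccc1Br)O[C@@H]2C(=O)OCC1CC1`, is 50000 nM, within the usual scatter of that, so no order between the two can be claimed. Compound 3 `C=C(C)[C@H]1CC=C(C)[C@@]2(O)[C@@H]1[C@H](c1ccccc1Br)O[C@@H]2C(=O)OC` differs from compound 2 by 2-bromophenyl in place of pyridin-2-yl on a saturated ring carbon. Compound 3 shares its aryl group with compound 1 and its ester with compound 2. Compound 3 is expected to come out near 50000 nM, with a range of 15000 nM to 150000 nM. The expected step of a 2.0-fold lower number from compound 2 to compound 3 (0.30 log units; within the scatter) stays within the scatter.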

Compound 3, half-maximal inhibitory concentration: 5000 nM
Compound 3: middle estimate off by 10-fold (1.00 log units), on the high side; the measured number lies below the stated range.
By their numbers in this assay, from the lowest: compound 3; then compounds 1 and 2 (each within the scatter of the next).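

In this assay, 2-bromophenyl in place of pyridin-2-yl on this saturated ring carbon gives a 20-fold lower number from compound 2 to compound 3 (1.30 log units; beyond the scatter) with the methyl ester held fixed, so the aryl group at this position matters, which compounds 1 and 2 could not show. With 2-bromophenyl held fixed, hydrogen in place of cyclopropyl in the ester gives a 10-fold lower number from compound 1 to compound 3 (1.00 log units; beyond the scatter), so the ester matters as well. Open, on these data alone, is whether the bromine or the ring itself carries the aryl step, which unsubstituted phenyl at this position would separate, and how a longer chain in the ester would read. Nothing measured yet accounts for either step.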